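The source may hold more compounds than are shown below. What is called first, only, known or untested is meant among the compounds shown, and "the series" means these compounds.

Compound 1 `O=C(O)c1ccc(C=C2CCN(C(=O)C(C3CCCCC3)C3CCCCC3)CC2)cc1`: 60 nM
Compound 2 `O=C(O)c1ccc(C=C2CCN(C(=O)C(c3ccccc3)c3ccccc3)CC2)c(F)c1`: 410 nM
Compound 3 `O=C(O)c1ccc(C=C2CCN(C(=O)C(c3ccccc3)c3ccccc3)CC2)cc1`: 530 nM

In an assay on isolated protein for inhibition of 3-oxo-5-alpha-steroid 4-dehydrogenase 2 (Homo sapiens) (on this read-out higher numbers stand for weaker inhibition and lower numbers for stronger inhibition), compound 1 gives the lowest of the three numbers; compound 2 stands at 410 nM and compound 3 at 530 nM, both beyond the scatter from compound 1. Compound 4 `O=C(O)c1ccc(C=C2CCN(C(=O)C(C3CCCCC3)C3CCCCC3)CC2)c(F)c1` differs from compound 1 by fluoro in place of hydrogen on an aromatic carbon. For the measured compounds named here, the only measured step that bears on this change runs the other way, on a different pair of compounds: a 1.3-fold higher number from compound 2 to compound 3 (0.11 log units; within the scatter). Because that step stayed within the scatter, the same change in the opposite direction is expected to leave this assay essentially unchanged, and the step from compound 1 is estimated as a 1.2-fold lower number from compound 1 to compound 4 (0.08 log units; within the scatter). Compound 4 is therefore expected to give 50 nM, within a range from 25 nM to 120 nM.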

Compound 4, half-maximal inhibitory concentration: 11 nM
Estimate against measurement, compound 4: 4.5-fold (0.66 log units) above; measured number below the stated range.
By their numbers in this assay, from the lowest: compound 4; then compound 1; then compounds 2 and 3 (each within the scatter of the next).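

In this assay the change from hydrogen to fluoro at this aromatic carbon brings stronger inhibition on the core of compound 1, with a 5.5-fold lower number from compound 1 to compound 4 (0.74 log units; beyond the scatter) as its step, whereas the earlier pair showed no change beyond the scatter. The same change therefore cannot be carried unchanged from one of these two cores to the other: the same change on two cores in this assay, a 1.3-fold higher number (0.11 log units; within the scatter) from compound 2 to compound 3 and a 5.5-fold higher number (0.74 log units; beyond the scatter) from compound 4 to compound 1, 4.2-fold (0.63 log units) apart, beyond the scatter of two such steps

On these data alone, whether chloro or methyl at this carbon would match fluoro remains open. So does what fluoro would do on other carbons of this ring.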